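A few compounds are considered here, and "the series" means these few. Any claim that something is new, unique, unknown or untested is made for them only; others in the source may bear on it.

In a functional assay on HUVEC cells (Homo sapiens), read by scintillation counting and thymidine incorporation, with a stated time of 24 h (a higher number here means a weaker inhibitor, a lower number a stronger inhibitor), compound 1 `CCC(C)n1ncn(-c2ccc(N3CCN(c4ccc(OC[C@@H]5CO[C@@](CN6CCNCC6)(c6ccc(Cl)cc6Cl)O5)cc4)CC3)cc2)c1=O` gives 608 nM and compound 2 `CCC(C)n1ncn(-c2ccc(N3CCN(c4ccc(OC[C@@H]5CO[C@@](Cn6cc(C)nc6C)(c6ccc(Cl)cc6Cl)O5)cc4)CC3)cc2)c1=O` gives 492 nM. These two numbers lie within the scatter of each other, so compound 2 stands level with compound 1. Compound 3 `CCC(C)n1ncn(-c2ccc(N3CCN(c4ccc(OC[C@@H]5CO[C@@](Cn6nnnc6C)(c6ccc(Cl)cc6Cl)O5)cc4)CC3)cc2)c1=O` has 5-methyl-1H-tetrazol-1-yl in place of 2,4-dimethyl-1H-imidazol-1-yl on a saturated chain carbon bound to a saturated ring carbon. Going by the values given here, the only measured exchange at this place, a 1.2-fold lower number from compound 1 to compound 2 (0.09 log units; within the scatter), stayed within the scatter. No step beyond the scatter is therefore expected, and no direction is favoured, with an estimated 1.1-fold higher number from compound 2 to compound 3 (0.05 log units; within the scatter). For compound 3 the estimated value is 550 nM, with an expected range of 230 nM to 1300 nM.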

Compound 3, half-maximal inhibitory concentration: 101 nM
Beside the measured number, compound 3's estimate is 5.4-fold (0.74 log units) above it; measured number outside the range, below it.
By their numbers in this assay, from the lowest: compound 3; then compounds 2 and 1 (each within the scatter of the next).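

On a saturated chain carbon bound to a saturated ring carbon, the earlier exchange left the number within the scatter, but 5-methyl-1H-tetrazol-1-yl shows that the group here can matter in this assay. Replacing 2,4-dimethyl-1H-imidazol-1-yl gives a 4.9-fold lower number from compound 2 to compound 3 (0.69 log units; beyond the scatter) and replacing piperazin-1-yl gives a 6.0-fold lower number from compound 1 to compound 3 (0.78 log units; beyond the scatter), so the tetrazole stands apart from both earlier groups. Nothing available explains this difference. The compounds shown leave open whether the methyl group is needed, since unsubstituted 1H-tetrazol-1-yl does not appear among them. They also leave open how a 1H-1,2,4-triazol-1-yl group would read at this place.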